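Swapping the aryl sulfonamide for a butylamide tail

The source may hold more compounds than are shown below. What is called first, only, known or untested is meant among the compounds shown, and "the series" means these compounds.

Measured compounds:
- compound 1, `CN(c1ccccc1CCCn1nnnc1[C@@H](COCc1ccccc1)NC(=O)C(C)(C)N)S(C)(=O)=O`: in an assay on isolated protein for displacement of a labelled ligand from growth hormone secretagogue receptor type 1 (Homo sapiens), with a stated time of 1 h (a lower number here means a stronger inhibitor, a higher number a weaker inhibitor), compound 1 gives 1720 nM.
- compound 2, `CC(C)(N)C(=O)N[C@H](COCc1ccccc1)c1nnn(Cc2ccccc2NS(C)(=O)=O)n1`: in this assay compound 2 reaches only a limit of the assay, > 5000 nM.
- compound 3, `CC(C)(N)C(=O)N[C@H](COCc1ccccc1)c1nnn(CC#N)n1`: in this assay compound 3 likewise reaches only a limit, > 5000 nM.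

Among the compounds with values here, compound 1 is thus the only compound with a real number; the other two sit at the limit of > 5000 nM in this assay, at which 2 of the 3 values shown sit. Within the data shown here, the sole step between measured compounds, a step that the two limits leave unreadable from compound 2 to compound 3, runs between two limits and its size cannot be read.

Compound 4, `CCCCNC(=O)CCCn1nnnc1[C@@H](COCc1ccccc1)NC(=O)C(C)(C)N`, differs from compound 1 by butylcarbamoyl in place of 2-(methyl(methylsulfonyl)amino)phenyl on a saturated chain carbon, three bonds along the chain from an aromatic nitrogen. No readable measured step bears on this change. The expectation for compound 4 in this assay is therefore a loose one, a step of a 2.0-fold higher number from compound 1 to compound 4 (0.31 log units; beyond the scatter) toward weaker binding. Compound 4 is estimated at 3500 nM, in the range 800 nM to 15000 nM.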

Compound 4, inhibition constant: 1780 nM
Estimate against measurement, compound 4: 2.0-fold (0.29 log units) above; the measured number falls inside the stated range.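

In this assay, the exchange at this position gives a 1.0-fold higher number from compound 1 to compound 4 (0.01 log units; within the scatter). Within the data shown here, this is the first step here that can be read, and it shows that neither the aromatic ring nor the sulfonyl group of compound 1 is needed for this level of binding, since butylcarbamoyl, with no ring and fewer heavy atoms, serves equally well. The other values are not numbers but a limit of the assay: the limit of > 5000 nM in this assay, at which 2 of the 4 values shown sit.

Going by these compounds, whether any group in this place binds more strongly remains open. A carboxylic acid, an amine or a longer chain in the same place could test this.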